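The source may report more compounds than this note shows. Statements on the series, on what has been measured and on what is new or still open speak of the compounds shown alone.

Measured so far in a functional assay on SW-620 cells (Homo sapiens) for inhibition, read by sulforhodamine B assay, with a stated time of 48 h; on this read-out higher numbers stand for weaker inhibition of growth and lower numbers for stronger inhibition of growth:
compound 3, `COc1ccc(C(=O)/C=C/c2cc(-c3cc(OC)c(OC)c(OC)c3)n[nH]2)cc1OC`: 1370 nM
compound 1, `COc1cc(-c2cc(/C=C/C(=O)c3ccc(N)cc3)[nH]n2)cc(OC)c1OC`: 2050 nM
compound 2, `COc1cc(-c2cc(/C=C/C(=O)c3ccc(Cl)c(Cl)c3)[nH]n2)cc(OC)c1OC`: 8630 nM

Going by the values given here, compound 3 holds the lowest of the three numbers in this assay, but the step of a 1.5-fold lower number from compound 1 to compound 3 (0.18 log units; within the scatter) is within the scatter, so compound 3 and compound 1 are not separated; only the step of a 6.3-fold lower number from compound 2 to compound 3 (0.80 log units; beyond the scatter) sets compound 3 apart, and the step of a 4.2-fold higher number from compound 1 to compound 2 (0.62 log units; beyond the scatter) likewise puts compound 2 at the weak end.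

Compound 4, `COc1ccc(C(=O)/C=C/c2cc(-c3cc(OC)c(OC)c(OC)c3)n[nH]2)cc1`, differs from compound 3 by hydrogen in place of methoxy on an aromatic carbon. Among the compounds with values here, no measured step removes a methoxy from this aryl ring; the three measured steps all exchange the whole aryl group on the carbonyl carbon, and the nearest of them, the exchange of 4-aminophenyl for 3,4-dimethoxyphenyl, stayed within the scatter. A change of one methoxy on the same ring is smaller than any of those exchanges, so the expected effect in this assay is a step of no more than modest size, if any, with a slight lean toward a higher number given that the dimethoxy pattern gave the lowest value seen.

The expected step is a 1.5-fold higher number from compound 3 to compound 4 (0.16 log units; within the scatter). Compound 4 is therefore estimated at 2000 nM, with a range from 800 nM to 5000 nM.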

Compound 4, concentration for 50% growth inhibition: 1620 nM
For compound 4 the middle estimate is 1.2-fold (0.09 log units) above the measured one; low and high end bracket the measured number.
By their numbers in this assay, from the lowest: compounds 3, 4 and 1 (each within the scatter of the next); then compound 2.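

In this assay, going by these compounds alone, this is the first change of a single substituent on the aryl group on the carbonyl carbon: the step 3,4-dimethoxyphenyl to 4-methoxyphenyl gives a 1.2-fold higher number from compound 3 to compound 4 (0.07 log units; within the scatter), so hydrogen and methoxy on this aromatic carbon, ortho to a methoxy group, are not separated. The other substituent on this ring can also differ without a separation, as methoxy in place of amino gives a 1.3-fold lower number from compound 1 to compound 4 (0.10 log units; within the scatter), while 4-methoxyphenyl in place of 3,4-dichlorophenyl gives a 5.3-fold lower number from compound 2 to compound 4 (0.73 log units; beyond the scatter). Among these four compounds, only compound 2 therefore stands apart, with compound 1, compound 3 and compound 4 forming one group that the scatter does not divide, and no data here bear on what lies behind these steps.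

Still open, from the compounds shown here alone, is whether the higher number of compound 2 needs both chlorines, and how a single chloro, a hydroxy group or a carboxylic acid on this aryl ring would read in this assay. Also open, going by these compounds, is whether a methoxy group on the other aryl group of the shared core can be replaced by hydrogen with as little consequence.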